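This account rests on a few compounds, and the source may have more. Where it says the series, first, only, none or still open, it means among the compounds named here.

Measured so far in an ADME assay for permeability, using PAMPA; on this read-out higher numbers stand for higher permeability and lower numbers for lower permeability
Compound 1 `COc1cc(N2CCN(C(=O)N3CCC(O)C3)CC2)ccc1Nc1nc(NC2CCCCC2)c2nc[nH]c2n1` gives "impermeable" (no number reported)
Compound 2 `COc1cc(N2CCN(CC3CCOC3)CC2)ccc1Nc1nc(NC2CCCCC2)c2nc[nH]c2n1` gives 1870 10^-6 cm/s
Compound 3 `COc1cc(N2CCC(CC(=O)N3CCOCC3)CC2)ccc1Nc1nc(NC2CCCCC2)c2nc[nH]c2n1` gives 409 10^-6 cm/s

Of the two compounds with a number, compound 3 (409 10^-6 cm/s) stands lowest, and the gap to compound 2 (1870 10^-6 cm/s) lies beyond the scatter. Compound 1 has no number to compare. Compound 4 `CCN(CC)CC1CCN(c2ccc(Nc3nc(NC4CCCCC4)c4nc[nH]c4n3)c(OC)c2)CC1` differs from compound 3 in one place diethylamino in place of (morpholin-4-yl)carbonyl on a saturated chain carbon bound to a saturated ring carbon with diethylamino in place of (morpholin-4-yl)carbonyl on a saturated chain carbon bound to a saturated ring carbon. Among the measured compounds shown here, no measured pair differs in just one place, so the guide is thin: compound 2 also has no carbonyl and gives 1870 10^-6 cm/s in this assay as a single reference. A small upward step is expected (a 1.7-fold higher number from compound 3 to compound 4 (0.23 log units; within the scatter)). Compound 4 is estimated at 700 10^-6 cm/s (expected range 150 10^-6 cm/s to 2200 10^-6 cm/s).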

Compound 4, apparent permeability: 480 10^-6 cm/s
Estimate against measurement, compound 4: 1.5-fold (0.16 log units) above, and the stated range covers the measured number.
By their numbers in this assay, from the lowest: compounds 3 and 4 (each within the scatter of the next); then compound 2.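

In this assay, diethylamino in place of (morpholin-4-yl)carbonyl on a saturated chain carbon bound to a saturated ring carbon gives a 1.2-fold higher number from compound 3 to compound 4 (0.07 log units; within the scatter) so at this place the read-out does not separate the two groups. The wider change, 4-((diethylamino)methyl)piperidin-1-yl in place of 4-((oxolan-3-yl)methyl)piperazin-1-yl on an aromatic carbon, gives a 3.9-fold lower number from compound 2 to compound 4 (0.59 log units; beyond the scatter) and so it does separate those two compounds. Nothing available here explains either step. Still open, on these data alone, is whether a cyclic amine such as pyrrolidine at this place would read like diethylamino, and whether a carboxylic acid would.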